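Removing a chloro group on two related cores

The source may hold more compounds than are shown below. What is called first, only, known or untested is meant among the compounds shown, and "the series" means these compounds.

Compound 1 `COc1ncc(-c2ccc3c(c2)N(c2ccccc2)C(=O)CO3)cc1NS(=O)(=O)c1ccc(F)cc1` and compound 2 `COc1ncc(-c2ccc3c(c2)N(c2ccc(Cl)cc2)C(=O)CO3)cc1NS(=O)(=O)c1ccc(F)cc1` share one core, while compound 3 `O=C1COc2ccc(-c3cnc4ccccc4c3)cc2N1c1ccc(Cl)cc1` is built on another. In a functional assay on HepG2 cells (Homo sapiens) for antiproliferative activity, read by MTT assay, with a stated time of 72 h (on this read-out lower numbers stand for stronger inhibition and higher numbers for weaker inhibition), compound 1 gives 14000 nM, compound 2 gives 17900 nM, and compound 3 gives 32700 nM. The difference between the two cores is not broken down here; the numbers of compound 2 and compound 3 lie within the scatter of each other, whereas compound 3 and compound 1 lie beyond it. On the first core the change hydrogen in place of chloro on an aromatic carbon produced a 1.3-fold lower number from compound 2 to compound 1 (0.11 log units; within the scatter). Compound 4 `O=C1COc2ccc(-c3cnc4ccccc4c3)cc2N1c1ccccc1` has not yet been measured; it differs from compound 3 by hydrogen in place of chloro on an aromatic carbon, the same kind of change carried out on the second core. Among the measured compounds shown here, because the only measured example of this change, a 1.3-fold lower number from compound 2 to compound 1 (0.11 log units; within the scatter), is small, the expected step in this assay is likewise small, estimated as a 1.3-fold lower number from compound 3 to compound 4 (0.10 log units; within the scatter). On that basis compound 4 is expected to give 26000 nM, with an estimated range from 11000 nM to 60000 nM.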

Compound 4, half-maximal inhibitory concentration: > 40000 nM
Compound 4: a limit, no number (the forecaster's own chance of this, stated with the estimate: 15%); at least 1.5-fold (0.18 log units) between middle value and limit.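

In this assay compound 4 gives > 40000 nM, which is a limit of the assay and not a number. Replacing chloro with hydrogen on the second core, the change from 4-chlorophenyl to phenyl, gives an at least 1.2-fold higher number from compound 3 to compound 4 (0.08 log units; that floor lies within the scatter), so this step can be read only as a floor, and its comparison with the step on the first core remains unresolved: the same change on two cores in this assay, a 1.3-fold lower number (0.11 log units; within the scatter) from compound 2 to compound 1 and an at least 1.2-fold higher number (0.08 log units; that floor lies within the scatter) from compound 3 to compound 4; the limit leaves it open whether they differ The result therefore does not show whether this change carries from one core to the other with the same size or direction, and it rests on just two matched pairs, one of them ending in a limit: the limit of > 40000 nM in this assay, at which 1 of the 4 values shown sits.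

The compounds shown leave open how other groups at this place on the phenyl ring, such as fluoro, methoxy or an amine, would read on either core. They also leave open how the same change from chloro to hydrogen would read on any core beyond these two.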